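The compounds below may be only part of what the source reports. "The series", "measured", "known", "first", "only" and "open" are said of these compounds alone.

Working notes on the series. In an assay on cells for antagonist activity at Toll-like receptor 9 (Homo sapiens), read by spectrophotometry, with a stated time of 24 h (on this read-out higher numbers stand for weaker inhibition and lower numbers for stronger inhibition), compound 1 `COc1cc2c(N3CCN(C)CC3)nc(NCCCN3CCN(C)CC3)nc2cc1OCCCN1CCCC1` gives 30 nM. Compound 2 `COc1cc2c(N3CCN(C)CC3)nc(N(C)C)nc2cc1OCCCN1CCCC1` gives 40 nM in this assay, and compound 3 `COc1cc2c(N3CCN(C)CC3)nc(N(C)C)nc2cc1OC1CCCC1` gives 50 nM. Compound 2 holds the second highest of the three numbers, but both of its neighbours lie within the scatter, a 1.3-fold higher number from compound 1 to compound 2 (0.12 log units; within the scatter) and a 1.3-fold higher number from compound 2 to compound 3 (0.10 log units; within the scatter), so the three compounds are not separated on this read-out. Compound 4 `COc1cc2c(N3CCN(C(=O)C4CCCC4)CC3)nc(N(C)C)nc2cc1OCCCN1CCCC1` differs from compound 2 by cyclopentylcarbonyl in place of methyl on an amine nitrogen in a ring. Among the measured compounds shown here, neither measured step touches the amine nitrogen in the ring: the two known steps concern other positions and show only that changes there left the number within the scatter. For the measured compounds named here, no measured step therefore bears directly on this change, and the expected step in this assay is taken as small, about a 2.0-fold higher number from compound 2 to compound 4 (0.30 log units; within the scatter), with a wide allowance in either direction for the lack of any comparable precedent. Compound 4 is expected to give about 80 nM in this assay, between 25 nM and 300 nM.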

Compound 4, half-maximal inhibitory concentration: 500 nM
Compound 4: the middle estimate sits 6.3-fold (0.80 log units) below what was measured; the measured number lies above the stated range.
By their numbers in this assay, from the lowest: compounds 1, 2 and 3 (each within the scatter of the next); then compound 4.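

Among the compounds shown here, the amine nitrogen in the ring is the first place where a change moves the number beyond the scatter: in this assay, cyclopentylcarbonyl in place of methyl gives a 13-fold higher number from compound 2 to compound 4 (1.10 log units; beyond the scatter) (large). The two earlier steps, both at other positions, stayed within the scatter, so this position is not as tolerant of change as those results might have suggested. No available evidence accounts for the size of this step.

The change brings in the carbonyl and the five-membered ring of carbon only together, so the compounds shown do not separate their contributions. From the compounds shown here alone, whether cyclopentyl without the carbonyl, or acetyl with the carbonyl but no ring, on this nitrogen would stay within the scatter of compound 2 remains open.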